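Three inactive benzamides and a tert-butoxycarbonyl to acetyl swap

This account rests on a few compounds, and the source may have more. Where it says the series, first, only, none or still open, it means among the compounds named here.

The study measured three compounds in an assay on isolated protein for inhibition of protein deacetylase HDAC6 (Homo sapiens), read by fluorescence, with stated times of 3 h and 60 min; on this read-out lower numbers stand for stronger inhibition and higher numbers for weaker inhibition:

compound 1, `Nc1ccccc1NC(=O)c1ccc(CNC2=N[C@@H](Cc3ccccc3)CS2)cc1`, gives > 20000 nM in this assay, a limit of the assay rather than a number.
compound 2, `CC(C)(C)OC(=O)N1C(NCc2ccc(C(=O)Nc3ccccc3N)cc2)=NC(=O)C1Cc1c[nH]c2ccccc12`, gives > 20000 nM in this assay, again a limit.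
compound 3, `Nc1cc2ccccc2cc1NC(=O)c1ccc(CNc2nccc(-c3cccnc3)n2)cc1`, gives > 20000 nM in this assay, also a limit.

Compound 2 therefore stands where the other two stand, at the limit of > 20000 nM in this assay, at which 3 of the 3 values shown sit; no number separates it from compound 1 or compound 3, and nothing in these values ranks the three against each other.

Compound 4, `CC(=O)N1C(NCc2ccc(C(=O)Nc3ccccc3N)cc2)=NC(=O)C1Cc1c[nH]c2ccccc12`, has not yet been measured in this assay. It differs from compound 2 by methyl in place of tert-butoxy on a carbonyl carbon. The change leaves the core and the benzamide portion of compound 2 untouched. No measured pair with a single difference exists among these compounds, so the size of this step cannot be read from data. The expected step that the limit leaves unreadable from compound 2 to compound 4 is none beyond the scatter. Compound 4 is estimated at 30000 nM in this assay, with a range from 5000 nM to 100000 nM, most likely reported again only as a limit.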

Compound 4, half-maximal inhibitory concentration: > 20000 nM
Compound 4 gave a limit, no number; the forecaster's own chance of this, stated with the estimate: 80%; the middle value lies beyond the limit too.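

No step can be read from compound 2 to compound 4, as each gives only a limit, and the tert-butoxycarbonyl to acetyl swap therefore has no readable size. The compounds shown leave open which change, if any, would yield an actual number rather than a limit.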